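Longer Ester Chains and Cytotoxicity on Lung Cancer Cells

The source may report more compounds than this note shows. Statements on the series, on what has been measured and on what is new or still open speak of the compounds shown alone.

Three compounds were measured in a functional assay on A549 cells (Homo sapiens) for cytotoxicity, read by MTT assay, with a stated time of 24 h, tested at 60 uM; a higher number here means a weaker effect of the compound at the concentration tested, a lower number a stronger effect:

Compound 1, `CCOC(=O)CCC(=O)N1CCN(CCCOc2cc3c(Nc4ccc(F)c(Cl)c4)ncnc3cc2OC)CC1`: 61.6%
Compound 2, `CCCOC(=O)CCC(=O)N1CCN(CCCOc2cc3c(Nc4ccc(F)c(Cl)c4)ncnc3cc2OC)CC1`: 70.4%
Compound 3, `CCCCCCCOC(=O)CCC(=O)N1CCN(CCCOc2cc3c(Nc4ccc(F)c(Cl)c4)ncnc3cc2OC)CC1`: 35.7%

Compound 3 shows the strongest effect of the three, as a number 25.9 percentage points lower from compound 1 to compound 3 (beyond the scatter) and a number 34.7 percentage points lower from compound 2 to compound 3 (beyond the scatter) show. Compound 4, `CCCCCCCCOC(=O)CCC(=O)N1CCN(CCCOc2cc3c(Nc4ccc(F)c(Cl)c4)ncnc3cc2OC)CC1`, is not yet measured. It differs from compound 3 by methyl in place of hydrogen on a saturated chain carbon, seven bonds along the chain from an oxygen next to a carbonyl group. The same kind of change, occurring twice in all, was made from compound 1 to compound 2, (methyl in place of hydrogen on a saturated chain carbon, two bonds along the chain from an oxygen next to a carbonyl group), with the step of a number 8.8 percentage points higher from compound 1 to compound 2 (within the scatter). The cores of those two pairs differ by pentyl in place of hydrogen on a saturated chain carbon, two bonds along the chain from an oxygen next to a carbonyl group, and the place is not the same: two bonds along the chain in the earlier pair, seven bonds along the chain here. Because a number 8.8 percentage points higher from compound 1 to compound 2 (within the scatter) was within the scatter, the expected step of a number 4.7 percentage points lower from compound 3 to compound 4 (within the scatter) is small. Compound 4 is estimated at 31%.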

Compound 4, a percentage reported as activity, at one concentration (the size of the read-out at that concentration, not a potency): 26%
The estimate for compound 4 lay 5 percentage points above the measured number, within the range that was stated.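

In this assay, the methyl step gave a number 9.7 percentage points lower from compound 3 to compound 4 (within the scatter), against a number 8.8 percentage points higher from compound 1 to compound 2 (within the scatter) on the other core, so the same change did not carry over with the same size: the same change on two cores in this assay, a number 8.8 percentage points higher (within the scatter) from compound 1 to compound 2 and a number 9.7 percentage points lower (within the scatter) from compound 3 to compound 4, 18.5 percentage points apart, beyond the scatter of two such steps

The pentyl change also differed with its starting point, giving a number 44.4 percentage points lower from compound 2 to compound 4 (beyond the scatter) against a number 25.9 percentage points lower from compound 1 to compound 3 (beyond the scatter): the same change on two cores in this assay, a number 25.9 percentage points lower (beyond the scatter) from compound 1 to compound 3 and a number 44.4 percentage points lower (beyond the scatter) from compound 2 to compound 4, 18.5 percentage points apart, beyond the scatter of two such steps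

The hexyl change gave a number 35.6 percentage points lower from compound 1 to compound 4 (beyond the scatter), so the largest chain changes here came with a stronger effect, but these four esters do not explain the differences between cores or show how the change would behave on a different core.

Going by these compounds, it remains open whether a longer chain, such as decyl, would continue this trend. A carboxylic acid in place of the ester is also an open case.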